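A few compounds are considered here, and "the series" means these few. Any claim that something is new, unique, unknown or untested is made for them only; others in the source may bear on it.

Compound 1 `CCCn1c(=O)n(CC(=O)O)c(=O)c2[nH]cnc21` in an assay on Cerebral cortex for binding affinity to adenosine receptor A1 (Cavia porcellus), read by radioligand binding (a higher number here means a weaker inhibitor, a lower number a stronger inhibitor), gives > 200000 nM, which is a limit of this assay and not a number.
Compound 2 `CCCn1c(=O)n(CCC(N)=O)c(=O)c2[nH]cnc21` gives 31500 nM.
Compound 3 `CCCn1c(=O)n(C)c(=O)c2c1ncn2CCC#N` gives 88600 nM.

Among the two numbers shown, compound 3 stands highest; its nearest neighbour is compound 2, which sits lower by more than the scatter. Compound 4 `CCCn1c(=O)n(C)c(=O)c2c1ncn2CCC(C)=O` differs from compound 3 by acetyl in place of cyano on a saturated chain carbon, two bonds along the chain from an aromatic nitrogen. Among the measured compounds shown here, the only measured step, an at least 6.3-fold lower number from compound 1 to compound 2 (0.80 log units; beyond the scatter), concerns a different place and a different exchange, so it does not directly bear on this change; no measured pair shows cyano against acetyl. With nothing pointing either way, the expected step of a 1.3-fold lower number from compound 3 to compound 4 (0.10 log units; within the scatter) is small, within the scatter. Compound 4 is therefore estimated at 70000 nM, between 20000 nM and 200000 nM.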

Compound 4, inhibition constant: 30000 nM
The estimate for compound 4 lay 2.3-fold (0.37 log units) above the measured number, and the stated range covers the measured number.
By their numbers in this assay, from the lowest: compounds 4 and 2 (each within the scatter of the next); then compound 3. At a limit, above all of these: compound 1.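

In this assay this position responds to a change of group: acetyl in place of cyano, on a saturated chain carbon two bonds along the chain from an aromatic nitrogen, gives a 3.0-fold lower number from compound 3 to compound 4 (0.47 log units; beyond the scatter). Among the compounds shown here, the earlier compounds held no pair that changed this chain, so this is the first measured sign that the group at its end affects the number. Nothing shown here explains the step. On these data alone, whether an amine or a hydroxyl group at the end of this chain, or a longer chain carrying the acetyl, would lower the number further remains open.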